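Second dimethoxyphenyl on the urea: an untested change

This account rests on a few compounds, and the source may have more. Where it says the series, first, only, none or still open, it means among the compounds named here.

Compound 1 `COc1ccc(NC(=O)Nc2nc(Sc3c[nH]c4ccccc34)cc(N3CCN(c4ccccn4)CC3)n2)cc1` gives 28400 nM in a functional assay on MDA-MB-231 cells (Homo sapiens) for inhibition, with a stated time of 72 h; a lower number here means a stronger inhibitor, a higher number a weaker inhibitor.
Compound 2 `COc1ccc(NC(=O)Nc2nc(Nc3cc(OC)cc(OC)c3)cc(Sc3c[nH]c4ccccc34)n2)cc1` gives 9460 nM in this assay.

Among the measured compounds shown here, compound 2 holds the lower of these two numbers; the only measured step is a 3.0-fold lower number from compound 1 to compound 2 (0.48 log units; beyond the scatter). Compound 3 `COc1cc(NC(=O)Nc2nc(Nc3cc(OC)cc(OC)c3)cc(Sc3c[nH]c4ccccc34)n2)cc(OC)c1` differs from compound 2 by 3,5-dimethoxyphenyl in place of 4-methoxyphenyl on an amide-type nitrogen. For the measured compounds named here, that single measured step alters a group on the shared core, not the urea end, so no measured step bears on this change. A step of a 1.1-fold lower number from compound 2 to compound 3 (0.02 log units; within the scatter) is therefore expected, within the scatter, in no clear direction. Compound 3 is estimated at 9000 nM, with a range from 3000 nM to 30000 nM.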

Compound 3, half-maximal inhibitory concentration: > 50000 nM
Compound 3 gave a limit, no number; the forecaster's own chance of this, stated with the estimate: 5%; middle value at least 5.5-fold (0.74 log units) from the limit.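

Changing the group on the amide-type nitrogen at the urea end is not neutral: 3,5-dimethoxyphenyl in place of 4-methoxyphenyl gives an at least 5.2-fold higher number from compound 2 to compound 3 (0.72 log units; beyond the scatter), so inhibition in this assay is weakened. This shows that the urea end, which the earlier step left untouched, matters for this read-out. For compound 3 the assay gives only a limit, not a number: the limit of > 50000 nM in this assay, at which 1 of the 3 values shown sits.

As far as these compounds go, the true size of the step therefore remains open. Also open, from the compounds shown here alone, is whether the loss follows the added methoxy or the moved one, and how a plain phenyl would behave here.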